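Methoxyphenyl on the ring amide nitrogen: series notes

A few compounds are considered here, and "the series" means these few. Any claim that something is new, unique, unknown or untested is made for them only; others in the source may bear on it.

Measured so far:
compound 1, `O=C1COc2ccc(-c3cccc(NS(=O)(=O)c4ccc(F)cc4)c3)cc2N1`: 32100 nM
compound 2, `COc1ncc(-c2ccc3c(c2)NC(=O)CO3)cc1NS(=O)(=O)c1ccc(F)cc1`: 8070 nM
compound 3, `COc1cccc(N2C(=O)COc3ccc(-c4cnc(OC)c(NS(=O)(=O)c5ccc(F)cc5)c4)cc32)c1`: 11200 nM

In a functional assay on A549 cells (Homo sapiens) for antiproliferative activity, read by MTT assay, with a stated time of 72 h (on this read-out lower numbers stand for stronger inhibition and higher numbers for weaker inhibition), compound 1 gives 32100 nM, the highest of the three numbers. Compound 2 gives 8070 nM, and compound 3 gives 11200 nM. The difference between the core of compound 1 and the core of compound 2 is not broken down here; what the two values show is that compound 2 sits at the lower number, with the gap beyond the scatter.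

Within the core of compound 2, the change to compound 3 is 3-methoxyphenyl in place of hydrogen on an amide-type nitrogen in a ring. The outcome was a 1.4-fold higher number from compound 2 to compound 3 (0.14 log units; within the scatter), so on that core the change is neutral as far as this read-out can tell.

Compound 4, `COc1cccc(N2C(=O)COc3ccc(-c4cccc(NS(=O)(=O)c5ccc(F)cc5)c4)cc32)c1`, is not yet measured. It differs from compound 1 by 3-methoxyphenyl in place of hydrogen on an amide-type nitrogen in a ring. The two place descriptions agree word for word, so this is the same change carried onto the core of compound 1, and it occurs twice among the compounds shown. Among the compounds with values here, only one measured instance exists, and it comes from a different core, so the transfer is an assumption rather than a pattern.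

The step from compound 1 to compound 4 is expected to be a 1.2-fold higher number from compound 1 to compound 4 (0.10 log units; within the scatter), resting on a 1.4-fold higher number from compound 2 to compound 3 (0.14 log units; within the scatter). Compound 4 is therefore estimated at 40000 nM in this assay, with the range expected to run from 15000 nM to 100000 nM.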

Compound 4, half-maximal inhibitory concentration: > 40000 nM
Compound 4 gave a limit, no number; the forecaster's own chance of this, stated with the estimate: 20%; the middle value sits exactly at the limit.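

In this assay compound 4 gives > 40000 nM, which is a limit of the assay and not a number: the limit of > 40000 nM in this assay, at which 1 of the 4 values shown sits.
Putting 3-methoxyphenyl in place of hydrogen on an amide-type nitrogen in a ring of the core of compound 1 can therefore be read only as a floor, an at least 1.2-fold higher number from compound 1 to compound 4 (0.09 log units; that floor lies within the scatter), and the comparison with the other core goes no further than this: the same change on two cores in this assay, a 1.4-fold higher number (0.14 log units; within the scatter) from compound 2 to compound 3 and an at least 1.2-fold higher number (0.09 log units; that floor lies within the scatter) from compound 1 to compound 4; the limit leaves it open whether they differ.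
Neither core shows a lower number after the change, which fits the change carrying over without any gain on this read-out, but it does not show that the size of the step is the same on both cores, and the transfer remains unconfirmed as a quantitative rule.

The compounds shown leave open whether anything other than 3-methoxyphenyl on the amide-type nitrogen, such as a plain methyl or a longer chain ending in an amine, would move the number on either core. They also leave open whether the same change would behave in the same way on any core beyond these two.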